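Five-Membered Ring Swap on a Shared Core: An Expectation

A few compounds are considered here, and "the series" means these few. Any claim that something is new, unique, unknown or untested is made for them only; others in the source may bear on it.

Compound 1, `CC(=O)Oc1ccc(-n2cccc2)cc1C(=O)O`: 42 mg/kg
Compound 2, `O=C(O)c1cc(-c2cccs2)ccc1O`: 60 mg/kg
Compound 3, `O=C(O)c1cc(-c2ccncn2)ccc1O`: > 200 mg/kg

Of the compounds shown here, three have so far been tested in a functional assay on the whole organism for inhibition, with Rattus norvegicus as the target, read by paw edema; a lower number here means that less compound is needed, a higher number that more compound is needed for the effect. Compound 1 gives 42 mg/kg and compound 2 gives 60 mg/kg. Of the two plain numbers, compound 2 holds the higher one, yet its gap to compound 1 lies within the scatter, so the two cannot be told apart. Compound 3 returns no number, only a limit of the assay, > 200 mg/kg. That ceiling is described as the limit of > 200 mg/kg in this assay, at which 1 of the 3 values shown sits.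

The unmeasured compound 4, `O=C(O)c1cc(-c2ccno2)ccc1O`, differs from compound 2 in a single place: 1,2-oxazol-5-yl in place of thiophen-2-yl on an aromatic carbon. No two measured compounds differ in exactly this way, so the size of the step has to be judged from what is shown. Compound 3 reaching only > 200 mg/kg weighs toward a weaker outcome for a ring of this kind. Compound 4 is therefore expected to need a higher dose, estimated at 110 mg/kg, with a plausible range from 45 mg/kg to 280 mg/kg. The expected step of a 1.8-fold higher number from compound 2 to compound 4 (0.26 log units; within the scatter) is a rise beyond the scatter, and there is a real chance that the assay reports only a limit.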

Compound 4, dose for half-maximal effect: 110 mg/kg
Compound 4: the middle estimate sits on the measured number at the digits printed, within the range that was stated.
By their numbers in this assay, from the lowest: compounds 1, 2 and 4 (each within the scatter of the next, the first and the last beyond it). At a limit, above all of these: compound 3.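

Among the compounds shown here, this swap is the first measured step at this position, on the aromatic carbon meta to the carboxy group and para to the hydroxy group, and it replaces thiophen-2-yl, a five-membered aromatic ring with 1 hetero atom, by 1,2-oxazol-5-yl, a five-membered aromatic ring with 2 hetero atoms. In this assay, the change gives a 1.8-fold higher number from compound 2 to compound 4 (0.26 log units; within the scatter), so compound 2 and compound 4 cannot be told apart, and this position accepts the exchange of one five-membered ring for the other without a measurable loss. Compound 3, which carries a different ring at the same place, gives no number, only a limit of the assay: the limit of > 200 mg/kg in this assay, at which 1 of the 4 values shown sits.

With a single step at this position, nothing shown can say which feature of a ring decides whether a compound gives a number or only reaches the limit. As far as these compounds go, it also remains open how this assay would respond to a plain phenyl ring, an amine or a longer carbon chain at this place, all of which would test more than the exchange of one aromatic ring for another.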